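The source may report more compounds than this note shows. Statements on the series, on what has been measured and on what is new or still open speak of the compounds shown alone.

Of the compounds shown here, two sharing one core have been measured so far. In an ADME assay on microsomes from liver (Homo sapiens) for metabolic stability, with a stated time of 10 min (on this read-out higher numbers stand for a more stable compound and lower numbers for a less stable compound), compound 1 (`COc1ccc(Nc2nc(Cl)cn([C@H](C)C3CC3)c2=O)c(C)n1`) gives 60%. Compound 2 (`COc1nc(C)c(Nc2nc(Cl)cn([C@H](C)C3CC3)c2=O)cc1C`) gives 55% in this assay, so the two cannot be told apart, and compound 2 stands level with compound 1 within the usual scatter.

The next compound is compound 3 (`CCOc1nc(C)c(Nc2nc(Cl)cn([C@H](C)C3CC3)c2=O)cc1C`), which has not yet been measured. It differs from compound 2 by methyl in place of hydrogen on a saturated chain carbon bound to an oxygen on an aromatic ring, that is, methoxy to ethoxy (methyl in place of hydrogen on a saturated chain carbon bound to an oxygen on an aromatic ring).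

Among the measured compounds shown here, only one measured step is available for comparison: a number 5 percentage points lower from compound 1 to compound 2 (within the scatter). That step also brought in a methyl, but on an aromatic carbon, so it bears on the new change only loosely. For the measured compounds named here, no measured step touches the methoxy group itself. A small move at most is therefore expected, and the expected step is a number 5 percentage points lower from compound 2 to compound 3 (within the scatter). This lies within the scatter, and its direction is tentative.

For compound 3 the estimated value in this assay is 50%, with an expected range from 35% to 65%.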

Compound 3, percent of the compound remaining: 81%
Beside the measured number, compound 3's estimate is 31 percentage points below it; measured number outside the range, above it.
By their numbers in this assay, from the lowest: compounds 2 and 1 (each within the scatter of the next); then compound 3.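

Among the compounds shown here, at the position of the alkoxy group, the change from methoxy to ethoxy gives the first step that clearly moves the read-out in this assay: a number 26 percentage points higher from compound 2 to compound 3 (beyond the scatter). The earlier step, a number 5 percentage points lower from compound 1 to compound 2 (within the scatter), also brought in a methyl, but on an aromatic carbon, and it stayed within the scatter, so in these two steps the same added group reads differently depending on where it sits, with the clear rise on a saturated chain carbon bound to an oxygen on an aromatic ring. Nothing at hand explains why the ethoxy compound stands higher than its methoxy partner.

The compounds shown leave open whether the rise continues with a longer chain such as propoxy, or whether a branched group such as isopropoxy reads the same way as ethoxy. They also leave open whether methoxy to ethoxy gives a similar step on the core of compound 1, as this change is so far read from a single pair.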